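This account rests on a few compounds, and the source may have more. Where it says the series, first, only, none or still open, it means among the compounds named here.

Compound 1 `CN1CCN(C(=O)c2c(NC(=O)NS(=O)(=O)c3ccccc3)sc3c2CCCCC3)CC1`: 9200 nM
Compound 2 `CCCCNC(=O)c1c(NC(=O)NS(=O)(=O)c2ccccc2)sc2c1CCCCC2`: 65200 nM
Compound 3 `O=C(Nc1sc2c(c1C(=O)NNc1ccccc1)CCCCC2)NS(=O)(=O)c1ccccc1`: 7000 nM

These three share a core and were compared in a functional assay on cells (Cancer cell lines, Homo sapiens) for inhibition, with a stated time of 48 h; on this read-out lower numbers stand for stronger inhibition of growth and higher numbers for weaker inhibition of growth. Compound 1 stands second highest of the three numbers. The step of a 1.3-fold lower number from compound 1 to compound 3 (0.12 log units; within the scatter) stays within the scatter, while the step of a 7.1-fold higher number from compound 1 to compound 2 (0.85 log units; beyond the scatter) goes beyond it.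

Compound 4 `O=C(Nc1sc2c(c1C(=O)N1CCN(c3ccccc3)CC1)CCCCC2)NS(=O)(=O)c1ccccc1` differs from compound 1 by phenyl in place of methyl on an amine nitrogen in a ring. For the measured compounds named here, two measured steps bear on this change. In the step of a 1.3-fold lower number from compound 1 to compound 3 (0.12 log units; within the scatter) a group carrying a phenyl ring took the place of the whole 4-methylpiperazin-1-yl with no change beyond the scatter. In the step of a 9.3-fold lower number from compound 2 to compound 3 (0.97 log units; beyond the scatter) anilino in place of butyl gave a markedly lower number. In both cases a phenyl-bearing group came with a lower or unchanged number, so a small drop, or no step beyond the scatter, is expected here. The step from compound 1 to compound 4 is expected to be a 1.7-fold lower number from compound 1 to compound 4 (0.22 log units; within the scatter). Compound 4 is therefore estimated at 5500 nM, within a range of 1800 nM to 16000 nM.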

Compound 4, concentration for 50% growth inhibition: 11500 nM
Estimate against measurement, compound 4: 2.1-fold (0.32 log units) below; the measured number falls inside the stated range.
By their numbers in this assay, from the lowest: compounds 3, 1 and 4 (each within the scatter of the next); then compound 2.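

In this assay, replacing methyl with phenyl on the amine nitrogen in the ring produced no change beyond the scatter: a 1.3-fold higher number from compound 1 to compound 4 (0.10 log units; within the scatter). For the compounds shown here, the 4-phenylpiperazin-1-yl group also could not be separated from anilinoamino on the carbonyl carbon, a 1.6-fold higher number from compound 3 to compound 4 (0.22 log units; within the scatter), whereas it did separate from butylamino, a 5.7-fold lower number from compound 2 to compound 4 (0.75 log units; beyond the scatter), leaving butylamino as the only one of the four groups on that carbon whose number stands apart. Nothing measured here accounts for these steps.

The compounds shown leave open whether this nitrogen tolerates other groups as well, such as a benzyl group or a plain hydrogen. They also leave open whether a shorter chain or a morpholin-4-yl group on the carbonyl carbon would track butylamino or the other three groups.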